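Adding a 3-methylbut-2-en-1-yl Group to an Inactive Scaffold

The compounds below may be only part of what the source reports. "The series", "measured", "known", "first", "only" and "open" are said of these compounds alone.

Measured compounds:
Compound 1, `C=CC(C)(C)c1[nH]c2ccc(C[C@@H](Cl)C(C)(C)O)cc2c1/C=C1\NC(=O)[C@H](C)NC1=O`: > 50000 nM
Compound 2, `C=CC(C)(C)c1[nH]c2ccccc2c1/C=C1\NC(=O)C(C)(OC)NC1=O`: > 50000 nM

In a functional assay on P388 cells (Mus musculus) for cytotoxicity, read by MTT assay, with a stated time of 72 h (on this read-out lower numbers stand for stronger inhibition and higher numbers for weaker inhibition), compound 1 gives > 50000 nM, which is a limit of the assay. In this assay compound 2 likewise gives > 50000 nM, also a limit of the assay. Compound 2 thus stands at the limit of > 50000 nM in this assay, at which 2 of the 2 values shown sit. Compound 3, `C=CC(C)(C)c1[nH]c2ccc(CC=C(C)C)cc2c1/C=C1\NC(=O)C(C)(OC)NC1=O`, has not been measured; it differs from compound 2 by 3-methylbut-2-en-1-yl in place of hydrogen on an aromatic carbon. With both neighbours sitting at a limit, no step beyond the scatter is expected in this assay, and a further limit is the most likely outcome. Compound 3 is expected to give about 60000 nM, between 15000 nM and 250000 nM, the expected step being a step that the limit leaves unreadable from compound 2 to compound 3.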

Compound 3, half-maximal inhibitory concentration: > 50000 nM
Compound 3 gave a limit, no number (the forecaster's own chance of this, stated with the estimate: 75%); the middle value does not contradict the limit.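

In this assay compound 2 and compound 3 each sit at a limit, so no step can be read between them. The compounds shown leave open whether 3-methylbut-2-en-1-yl in place of hydrogen changes cytotoxicity at all.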